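Methyl to fluoro on the shared core: compound 3

The compounds below may be only part of what the source reports. "The series", "measured", "known", "first", "only" and "open" are said of these compounds alone.

compound 1 `CS(=O)(=O)Nc1ccc(O)c2c1CCCC2c1c[nH]cn1`: < 10000 nM
compound 2 `Cc1ccc(NS(C)(=O)=O)c2c1C(c1c[nH]cn1)CCC2`: < 10000 nM

Compound 1 is `CS(=O)(=O)Nc1ccc(O)c2c1CCCC2c1c[nH]cn1`. In an assay on isolated protein (Cricetulus griseus) for binding affinity to Alpha-1B adrenergic receptor (Mesocricetus auratus), read by radioligand binding (a lower number here means a stronger inhibitor, a higher number a weaker inhibitor), compound 1 gives < 10000 nM, which is a limit of the assay and not a number. Compound 2 is `Cc1ccc(NS(C)(=O)=O)c2c1C(c1c[nH]cn1)CCC2`. In this assay compound 2 gives < 10000 nM, again a limit. Both measured values sit at the limit of < 10000 nM in this assay, at which 2 of the 2 values shown sit, so compound 2 stands only at that limit, with no number of its own.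

For the measured compounds named here, the single measured step, a step that the two limits leave unreadable from compound 1 to compound 2, is therefore of unknown size and direction.

Compound 3 is `CS(=O)(=O)Nc1ccc(F)c2c1CCCC2c1c[nH]cn1`. It differs from compound 2 by fluoro in place of methyl on an aromatic carbon. Going by the values given here, the measured step is the only one that changes a group on that aromatic carbon, and it bears on the new step only by analogy; its size is unreadable, so no direction can be taken from it. No step beyond the scatter is expected in this assay.

Compound 3 is estimated at 2000 nM, with a range from 200 nM to 10000 nM. The step that the limit leaves unreadable from compound 2 to compound 3 that this estimate implies is expected to be small, and compound 3 is expected most likely to return only a limit as well.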

Compound 3, inhibition constant: < 10000 nM
Compound 3: only a limit was reported; the forecaster's own chance of this, stated with the estimate: 70%; the middle value does not contradict the limit.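

Compound 3 gives < 10000 nM, a limit of the assay and not a number. For the compounds shown here, no step among compound 1, compound 2 and compound 3 can be read: the limit of < 10000 nM in this assay, at which 3 of the 3 values shown sit. The compounds shown leave open whether hydroxy, methyl and fluoro on that aromatic carbon differ at all in this assay.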